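Swapping an Acid Tail for a Hydroxycyclohexyl Ring

A few compounds are considered here, and "the series" means these few. Any claim that something is new, unique, unknown or untested is made for them only; others in the source may bear on it.

Compound 1, `O=[N+]([O-])c1cc(Cl)ccc1CNc1cc(C(F)(F)F)cc2[nH]ncc12`: 1700 nM
Compound 2, `O=C(O)CNc1cccc(CNc2cc(C(F)(F)F)cc3[nH]ncc23)c1`: > 100000 nM
Compound 3, `O=[N+]([O-])c1cc(Br)c(F)cc1CNc1cc(C(F)(F)F)cc2[nH]ncc12`: 1460 nM

All three were tested in an assay for inhibition of Tryptophan 2,3-dioxygenase (Homo sapiens), with stated times of 10 min and 60 min; on this read-out higher numbers stand for weaker inhibition and lower numbers for stronger inhibition. Compound 1 gives 1700 nM and compound 3 gives 1460 nM, two readings that sit within the usual scatter of each other. Going by the values given here, for compound 2 the reading > 100000 nM is a limit of the assay rather than a number, the only such reading among the three (the limit of > 100000 nM in this assay, at which 1 of the 3 values shown sits). Compound 4, `OC1CCCC(Nc2cccc(CNc3cc(C(F)(F)F)cc4[nH]ncc34)c2)C1`, has not yet been measured; it differs from compound 2 by 3-hydroxycyclohexyl in place of carboxymethyl on a nitrogen on an aromatic ring. Among the compounds with values here, no measured pair differs in a single place, so the size of this step cannot be read from the data. The step of an at least 3.3-fold lower number from compound 2 to compound 4 (0.52 log units; beyond the scatter) is expected to run toward stronger inhibition, beyond the scatter, though with wide uncertainty. Compound 4 is therefore expected to give 30000 nM, within a range from 5000 nM to 200000 nM.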

Compound 4, half-maximal inhibitory concentration: > 100000 nM
Compound 4: a limit, no number (the forecaster's own chance of this, stated with the estimate: 40%); at least 3.3-fold (0.52 log units) between middle value and limit.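

Going by these compounds alone, compound 2 and compound 4 both give a limit rather than a number, so no step between them can be read: the limit of > 100000 nM in this assay, at which 2 of the 4 values shown sit. As far as these compounds go, whether carboxymethyl or 3-hydroxycyclohexyl gives stronger inhibition stays open.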